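Methyl to hydrogen on the imidazole nitrogen of compound 1

The compounds below may be only part of what the source reports. "The series", "measured", "known", "first", "only" and "open" are said of these compounds alone.

Measured so far:
compound 1, `Cn1ccnc1/C=N/Nc1ccnc2cc(Cl)ccc12`, 17.1 uM
compound 2, `FC(F)(F)c1ccc(-c2n[nH]cc2/C=N/Nc2ccnc3cc(Cl)ccc23)cc1`, 1.2 uM

In a functional assay on KB cells (Homo sapiens) for cytotoxicity (on this read-out lower numbers stand for an effect already at smaller amounts and higher numbers for an effect only at larger amounts of compound), compound 1 gives 17.1 uM, the highest of the two numbers; compound 2 gives 1.2 uM, a gap beyond the scatter. Compound 3, `Clc1ccc2c(N/N=C/c3ncc[nH]3)ccnc2c1`, is not yet measured. It differs from compound 1 by hydrogen in place of methyl on an aromatic nitrogen, a change on an aromatic nitrogen of a five-membered aromatic ring with 2 nitrogen. For the measured compounds named here, no measured pair shows this change, so the step is expected to be small, a 1.1-fold lower number from compound 1 to compound 3 (0.06 log units; within the scatter), and could lie in either direction or within the scatter. Compound 3 is therefore estimated at 15 uM, between 5 uM and 50 uM.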

Compound 3, concentration for half-maximal effect: 19.5 uM
Estimate against measurement, compound 3: 1.3-fold (0.11 log units) below; the range from low to high includes it.
By their numbers in this assay, from the lowest: compound 2; then compounds 1 and 3 (each within the scatter of the next).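

In this assay, for the compounds shown here, hydrogen in place of methyl on the aromatic nitrogen gives a 1.1-fold higher number from compound 1 to compound 3 (0.06 log units; within the scatter), the first step here between compounds that differ in one place. At this position, then, the methyl can be lost without a change beyond the scatter. Nothing available explains this result.

From the compounds shown here alone, what remains open is whether a group larger than methyl on this nitrogen, such as an ethyl, a longer chain or a chain ending in an amine, would shift the number. Going by these compounds, it is also open whether the same change would give a similar step on the pyrazole-bearing compound 2.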